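The compounds below may be only part of what the source reports. "The series", "measured", "known", "first", "only" and "open" are said of these compounds alone.

Measured in a functional assay on WI-38 VA13 cells (Homo sapiens) for cytotoxicity; on this read-out higher numbers stand for an effect only at larger amounts of compound and lower numbers for an effect already at smaller amounts:
- compound 1 `O=C(Nc1ccc2nc(NC(=O)C3CCCCC3)sc2c1)c1ccccc1C(F)(F)F`: 0.024 ug/mL
- compound 2 `CCC(C)(C)C(=O)Nc1ccc2nc(NC(=O)C3CCCCC3)sc2c1`: 1 ug/mL
- compound 3 `NCCC(=O)Nc1nc2ccc(NC(=O)c3c(Cl)cccc3Cl)cc2s1`: 5.3 ug/mL

Compound 3 stands highest of the three numbers, nearer to compound 2 than to compound 1, both gaps beyond the scatter. Compound 4 `O=C(Nc1nc2ccc(NC(=O)c3c(Cl)cccc3Cl)cc2s1)OCc1ccccc1` differs from compound 3 in one place: benzyloxy in place of 2-aminoethyl on a carbonyl carbon. Among the measured compounds shown here, the single measured step, a 42-fold higher number from compound 1 to compound 2 (1.62 log units; beyond the scatter), exchanged an aromatic group for an alkyl group on a carbonyl carbon, though on the other carbonyl of the shared core. The present change runs the opposite way, an alkyl group giving way to a group that carries an aromatic ring, so a lower number for compound 4 in this assay is expected, of uncertain size, as a 5.3-fold lower number from compound 3 to compound 4 (0.72 log units; beyond the scatter). Compound 4 is estimated at 1 ug/mL, within 0.2 ug/mL to 5 ug/mL.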

Compound 4, half-maximal effective concentration: 0.018 ug/mL
For compound 4 the middle estimate is 56-fold (1.74 log units) above the measured one, outside the stated range (below it).
By their numbers in this assay, from the lowest: compounds 4 and 1 (each within the scatter of the next); then compound 2; then compound 3.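

Notes on the series: in this assay, the carbonyl carbon bearing the amide-type nitrogen also responds strongly to substitution, not only the other carbonyl of the shared core (a 290-fold lower number from compound 3 to compound 4 (2.47 log units; beyond the scatter)). This change loses 2-aminoethyl with its hydrogen-bond donor and gains benzyloxy with its six-membered aromatic ring, and this single pair cannot separate those differences. No measured evidence bears on the cause of the step.

Going by these compounds, it remains open whether the aromatic ring, the oxygen link or the loss of the amine accounts for the step. A benzyl group or a 2-aminoethoxy group at this carbonyl carbon would help separate these contributions.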